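Ether chain series: removing the nitrile toward compound 4

The source may report more compounds than this note shows. Statements on the series, on what has been measured and on what is new or still open speak of the compounds shown alone.

Compound 3 `C=CCc1cc(C(C)=O)c(O)cc1OCCCCCCCCC#N` stands second highest of the three numbers in an assay on isolated protein for inhibition of leukotriene B4 receptor 1 (Homo sapiens), tested at 10 uM (a higher number here means more inhibition at the concentration tested (going by the name of the read-out), a lower number less inhibition), where compound 3 gives 86%. Compound 2 `C=CCc1cc(C(C)=O)c(O)cc1OCCCCCCC#N` gives 97% in this assay, and compound 1 `C=CCc1cc(C(C)=O)c(O)cc1OCCCC#N` gives 47%. The measured steps run from compound 1 upward: a number 50 percentage points higher from compound 1 to compound 2 (beyond the scatter) and a number 39 percentage points higher from compound 1 to compound 3 (beyond the scatter), while a number 11 percentage points lower from compound 2 to compound 3 (beyond the scatter).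

Compound 4 `C=CCc1cc(C(C)=O)c(O)cc1OCCCCC` differs from compound 3 by hydrogen in place of 3-cyanopropyl on a saturated chain carbon, five bonds along the chain from an oxygen on an aromatic ring. Going by the values given here, no measured step removes the nitrile from the chain; the steps so far only change the length of the chain that carries it, so the bearing of those steps on this change is indirect. Of them, the nearest in size of group removed is a number 39 percentage points higher from compound 1 to compound 3 (beyond the scatter), which ties the shorter chain to the lower number. A step downward in this assay, beyond the scatter, is therefore expected: a number 46 percentage points lower from compound 3 to compound 4 (beyond the scatter). Compound 4 is estimated at 40%, within 10% to 75%.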

Compound 4, a percentage reported as inhibition, at one concentration (the size of the read-out at that concentration, not a potency): 60%
Beside the measured number, compound 4's estimate is 20 percentage points below it, and the stated range covers the measured number.
By their numbers in this assay, from the lowest: compound 1; then compound 4; then compound 3; then compound 2.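

Removing the 3-cyanopropyl group from this place, five bonds along the chain from an oxygen on an aromatic ring, lowers inhibition in this assay, with a number 26 percentage points lower from compound 3 to compound 4 (beyond the scatter) and a number 37 percentage points lower from compound 2 to compound 4 (beyond the scatter). The nitrile is still not required for inhibition at this concentration: the chain without it stands above the shortest nitrile chain, with a number 13 percentage points higher from compound 1 to compound 4 (beyond the scatter), so a nitrile at the chain end does not alone set the level reached. Nothing at hand gives a reason for these steps.

As far as these compounds go, it remains open whether a longer chain without a nitrile would match compound 2 and compound 3, which would separate the effect of chain length from that of the end group. Also open, from the compounds shown here alone, is how a carboxylic acid or an amine at the chain end would compare with the nitrile.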